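Shortening the cyclopentyl-bearing ether chain of compound 3

The source may report more compounds than this note shows. Statements on the series, on what has been measured and on what is new or still open speak of the compounds shown alone.

Among the measured compounds shown here, compound 3 `O=C(/C=C/c1ccc(O)cc1)c1c(O)cccc1OCCC1CCCC1` is the only compound here with a numbered result: in a functional assay on NCI-H23 cells (Homo sapiens) for antiproliferative activity, read by sulforhodamine B assay (on this read-out lower numbers stand for stronger inhibition of growth and higher numbers for weaker inhibition of growth), compound 3 gives 3370 nM. Compound 1 `CCCCCCOc1cccc(O)c1C(=O)/C=C/c1ccc(O)cc1` reaches only the limit of this assay, giving > 30000 nM. Compound 2 `CC(C)=CCOc1cccc(O)c1C(=O)/C=C/c1ccc(O)cc1` likewise sits at the limit, with > 30000 nM. Both limit values are summed up by the limit of > 30000 nM in this assay, at which 2 of the 3 values shown sit. Compound 4 `O=C(/C=C/c1ccc(O)cc1)c1c(O)cccc1OCC1CCCC1` differs from compound 3 by cyclopentyl in place of cyclopentylmethyl on a saturated chain carbon bound to an oxygen on an aromatic ring. The steps that touch this region, an at least 8.9-fold lower number from compound 1 to compound 3 (0.94 log units; beyond the scatter) and an at least 8.9-fold lower number from compound 2 to compound 3 (0.94 log units; beyond the scatter), show the cyclopentyl ring arriving in compound 3 from the two limit compounds, but neither alters chain length alone, so the direction of the new step is uncertain. The expected step is therefore small, a 1.5-fold higher number from compound 3 to compound 4 (0.17 log units; within the scatter), within or near the scatter. Compound 4 is estimated at 5000 nM, between 1500 nM and 20000 nM.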

Compound 4, concentration for 50% growth inhibition: 3160 nM
The estimate for compound 4 lay 1.6-fold (0.20 log units) above the measured number; low and high end bracket the measured number.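

Replacing cyclopentylmethyl with cyclopentyl on the saturated chain carbon bound to the oxygen leaves the read-out in this assay unchanged within the scatter, with a 1.1-fold lower number from compound 3 to compound 4 (0.03 log units; within the scatter). The ring-bearing side chain therefore also stands apart from the open chains in this shorter form, with an at least 9.4-fold lower number from compound 2 to compound 4 (0.97 log units; beyond the scatter) and an at least 9.4-fold lower number from compound 1 to compound 4 (0.97 log units; beyond the scatter). Both of these steps start from a limit of the assay, not a number: the limit of > 30000 nM in this assay, at which 2 of the 4 values shown sit.

Going by these compounds, whether a cyclohexyl ring, a phenyl ring or a longer chain ending in cyclopentyl would hold this level stays open.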